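This account rests on a few compounds, and the source may have more. Where it says the series, first, only, none or still open, it means among the compounds named here.

Working notes on the series. Compound 1 `CCCCc1ccc(Nc2nc3cc(Oc4ccnc(C(=O)NC)c4)ccc3s2)cc1` and compound 2 `CNC(=O)c1cc(Oc2ccc3sc(Nc4ccc(C(C)C)cc4)nc3c2)ccn1` differ only in one group on the shared core. In an ADME assay on Caco-2 cells (Homo sapiens) for permeability, in the apical to basolateral direction (a higher number here means that the compound crosses the layer faster, a lower number that the compound crosses the layer more slowly), compound 1 gives 10 10^-6 cm/s, and in this assay compound 2 gives 10 10^-6 cm/s. The step of no change at the digits printed from compound 1 to compound 2 (within the scatter) lies within the scatter, so compound 2 stands level with compound 1 on the numbers at hand; there is nothing to order between them.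

Compound 3 `CNC(=O)c1cc(Oc2ccc3sc(Nc4ccc(OC(F)(F)F)cc4)nc3c2)ccn1` has not yet been measured in this assay. It differs from compound 2 in one place: trifluoromethoxy in place of isopropyl on an aromatic carbon. For the measured compounds named here, the only measured step, no change at the digits printed from compound 1 to compound 2 (within the scatter), exchanged one alkyl group for another at this same place and left the read-out unchanged within the scatter. Going by the values given here, no measured step involves a trifluoromethoxy group, and no measured step exchanges an alkyl group for an oxygen-bearing group, so the measured data bear on this change only loosely. On that basis no step beyond the scatter is expected for no change at the digits printed from compound 2 to compound 3 (within the scatter), with the range kept wide to reflect the thin support. Compound 3 is therefore estimated at 10 10^-6 cm/s, expected between 5 10^-6 cm/s and 20 10^-6 cm/s.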

Compound 3, apparent permeability: 10 10^-6 cm/s
For compound 3 middle estimate and measured number coincide at the digits printed; low and high end bracket the measured number.
By their numbers in this assay, from the lowest: compounds 1, 2 and 3 (each within the scatter of the next).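

In this assay, the read-out at this position, on an aromatic carbon para to a large group, now covers more than alkyl groups: the exchange of isopropyl for trifluoromethoxy gives no change at the digits printed from compound 2 to compound 3 (within the scatter), and the exchange of butyl for trifluoromethoxy gives no change at the digits printed from compound 1 to compound 3 (within the scatter). For the compounds shown here, the earlier pair swapped only one all-carbon group for another, whereas this change brings in oxygen, fluorine and a hydrogen-bond acceptor, and the three compounds still cannot be put in any order on these numbers. Nothing available accounts for this flat result, so it stands as an observation without an explanation.

The compounds shown leave open whether the flat read-out would hold for a group at this place that carries a hydrogen-bond donor or a charge, such as a primary amine, a hydroxyl or a carboxylic acid. They also leave open how the read-out responds to a change anywhere else on the shared core, including the methyl amide, which stays the same in all three compounds.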